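Amide-to-ester change on the pyrrole carbonyl: cytotoxicity outlook

This account rests on a few compounds, and the source may have more. Where it says the series, first, only, none or still open, it means among the compounds named here.

Measured compounds:
compound 1 `CCn1c(C(=O)NCCN(C)C)ccc1C(CC)(CC)c1ccc(OCC(=O)C(C)(C)C)c(C)c1`: 2500 nM
compound 2 `CCn1c(C(=O)NCCCN(C)C)ccc1C(CC)(CC)c1ccc(OCC(=O)C(C)(C)C)c(C)c1`: 670 nM
compound 3 `CCN(CC)CCCNC(=O)c1ccc(C(CC)(CC)c2ccc(OCC(O)C(C)(C)C)c(C)c2)n1CC`: 2500 nM

In an ADME assay on L02 cells (Homo sapiens) for cytotoxicity, read by MTT assay, with a stated time of 48 h (a higher number here means a weaker inhibitor, a lower number a stronger inhibitor), compound 3 sits level with compound 1 at the digits shown, the two together giving the highest numbers of the three. Going by the values given here, compound 2 gives the lowest number; the one measured step, a 3.7-fold lower number from compound 1 to compound 2 (0.57 log units; beyond the scatter), is modest and lies beyond the scatter, and the gap between compound 3 and compound 2 is of the same size.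

Compound 4 `CCn1c(C(=O)OCc2ccc(F)cc2)ccc1C(CC)(CC)c1ccc(OCC(O)C(C)(C)C)c(C)c1` is the next member. Relative to compound 3 the change is (4-fluorobenzyl)oxy in place of (3-(diethylamino)propyl)amino on a carbonyl carbon. Among the compounds with values here, no measured step touches this kind of change: the single step on record concerns only the length of the amine-bearing chain on the amide nitrogen, and nothing measured alters the carbonyl substituent itself or removes the amine. On these data alone, the expectation for compound 4 therefore rests on compound 3 alone, whose value 2500 nM serves as the anchor, and the estimated step of no change at the digits printed from compound 3 to compound 4 (within the scatter) is set at no change beyond the scatter, with a wide range to reflect that the change is untested. Compound 4 is thus estimated at 2500 nM, expected between 700 nM and 9000 nM.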

Compound 4, half-maximal inhibitory concentration: 14900 nM
Compound 4: middle estimate off by 6.0-fold (0.78 log units), on the low side; measured number above the stated range.
By their numbers in this assay, from the lowest: compound 2; then compounds 1 and 3 (each within the scatter of the next); then compound 4.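

In this assay, the carbonyl substituent itself proves able to move the number: (4-fluorobenzyl)oxy in place of (3-(diethylamino)propyl)amino on the carbonyl carbon gives a 6.0-fold higher number from compound 3 to compound 4 (0.78 log units; beyond the scatter), whereas the earlier step changed only the length of the amine-bearing chain. The leaving and entering groups both count 9 heavy atoms, so this step comes with a change in composition and not in heavy-atom count: the two nitrogens and the hydrogen-bond donor leave, and a six-membered aromatic ring and a fluorine enter. No measurement on hand explains the step.

The step combines the loss of the amide nitrogen, the loss of the diethylamino group and the gain of the fluorinated aromatic ring, so the compounds shown cannot assign it to any one of these. An ester carrying a 3-(diethylamino)propyl chain, an amide carrying a 4-fluorobenzyl group, or a plain benzyl ester would each separate these parts of the change.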